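A few compounds are considered here, and "the series" means these few. Any claim that something is new, unique, unknown or untested is made for them only; others in the source may bear on it.

Compound 1, `C=CC1=C(C(=O)NCCC)C(c2ccc(Cl)c(Cl)c2)OC1`, in a functional assay on A549 cells (Homo sapiens) for cytotoxicity, read by MTT assay, with a stated time of 24 h (on this read-out higher numbers stand for weaker inhibition and lower numbers for stronger inhibition), gives > 100000 nM, which is a limit of the assay and not a number.
Compound 2, `C=CC1=C(C(=O)Nc2ccccc2)C(c2ccc(F)cc2)OC1`, in this assay gives > 100000 nM, likewise a limit.

Among the compounds with values here, compound 1 therefore stands at a limit in this assay, and the only other value shown, that of compound 2, is a limit as well; both sit at the limit of > 100000 nM in this assay, at which 2 of the 2 values shown sit. No order between compound 1 and compound 2 can be read from two limits, and neither can be called the stronger or the weaker.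

The change that leads from compound 1 to compound 3, `C=CC1=C(C(=O)O)C(c2ccc(Cl)c(Cl)c2)OC1`, is hydroxy in place of propylamino on a carbonyl carbon. Within the data shown here, no step between two measured compounds is available to guide the expectation, so it rests on compound 1 alone, whose reading of > 100000 nM in this assay already sits at the limit. Compound 3 is expected to stay at or beyond that limit, and the step from compound 1 to compound 3 is estimated at a step that the limit leaves unreadable from compound 1 to compound 3, that is, none beyond the usual scatter. For compound 3 in this assay the estimate is 200000 nM, with a range from 50000 nM to 1000000 nM, and the most likely outcome is that the assay again reports only a limit.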

Compound 3, half-maximal inhibitory concentration: > 100000 nM
Compound 3 ended at the assay's limit; the forecaster's own chance of this, stated with the estimate: 85%; the middle value lies beyond the limit too.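

Within the data shown here, compound 1 and compound 3 both stand at a limit and not at a number, so no step from one to the other can be read in this assay, and the swap of propylamino for hydroxy shows no readable effect: the limit of > 100000 nM in this assay, at which 3 of the 3 values shown sit.

The compounds shown leave open which change to the shared core, if any, would bring a reading inside the range of this assay.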